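Carboxy to ethyl: notes on a small series

This account rests on a few compounds, and the source may have more. Where it says the series, first, only, none or still open, it means among the compounds named here.

- compound 1 `O=C1Nc2ccccc2/C1=N/NC(=S)Nc1ccccc1`: 1470 nM
- compound 2 `O=C1Nc2ccccc2/C1=N/NC(=S)Nc1ccc(Cl)cc1`: 4990 nM
- compound 3 `O=C1Nc2ccccc2/C1=N/NC(=S)Nc1ccc(C(=O)O)cc1`: > 50000 nM (a limit, not a number)

All three values come from a functional assay on KB-V1 cells (Homo sapiens) for cytotoxicity, read by MTT assay, with a stated time of 72 h; on this read-out higher numbers stand for weaker inhibition and lower numbers for stronger inhibition. Compound 3 stands only at a limit, > 50000 nM. Compound 4 `CCc1ccc(NC(=S)N/N=C2\C(=O)Nc3ccccc32)cc1`, not yet measured, carries ethyl in place of carboxy on an aromatic carbon, para to a large group: ethyl in place of carboxy on an aromatic carbon.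

For the measured compounds named here, three measured steps bear on this change. Carboxy in place of hydrogen gave an at least 34-fold higher number from compound 1 to compound 3 (1.53 log units; beyond the scatter), and carboxy in place of chloro gave an at least 10-fold higher number from compound 2 to compound 3 (1.00 log units; beyond the scatter). Chloro in place of hydrogen gave a smaller change, a 3.4-fold higher number from compound 1 to compound 2 (0.53 log units; beyond the scatter). Going by the values given here, no measured compound carries ethyl, so the expectation rests on the two compounds without carboxy. Compound 4 is expected to fall in the region of compound 1 at 1470 nM and compound 2 at 4990 nM. The expected change is large and toward a lower number in this assay: an at least 16-fold lower number from compound 3 to compound 4 (1.22 log units; beyond the scatter). For compound 4 the estimated value is 3000 nM, with an expected range of 900 nM to 10000 nM.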

Compound 4, half-maximal inhibitory concentration: 1340 nM
For compound 4 the middle estimate is 2.2-fold (0.35 log units) above the measured one; the measured number falls inside the stated range.
By their numbers in this assay, from the lowest: compounds 4 and 1 (each within the scatter of the next); then compound 2. At a limit, above all of these: compound 3.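

In this assay, ethyl on this aromatic carbon, para to a large group, gives no change from hydrogen beyond the scatter: a 1.1-fold lower number from compound 1 to compound 4 (0.04 log units; within the scatter). So a group in place of hydrogen here need not raise the number, as chloro did, since ethyl in place of chloro gives a 3.7-fold lower number from compound 2 to compound 4 (0.57 log units; beyond the scatter) and ethyl in place of carboxy gives an at least 37-fold lower number from compound 3 to compound 4 (1.57 log units; beyond the scatter). Compound 3 stands only at a limit, so the step from carboxy gives a minimum and not a size: the limit of > 50000 nM in this assay, at which 1 of the 4 values shown sits.

The compounds shown leave open whether a longer chain, a methoxy group or an amine at this position would stay with ethyl and hydrogen or move toward chloro. They also leave open whether ethyl on another carbon of this ring would give the same number, and they offer no explanation for any of these steps.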